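This account rests on a few compounds, and the source may have more. Where it says the series, first, only, none or still open, it means among the compounds named here.

Two analogues of the shared core have been read in an assay for displacement of a labelled ligand from melanin-concentrating hormone receptor 1 (Homo sapiens), read by fluorescence; on this read-out lower numbers stand for stronger inhibition and higher numbers for weaker inhibition. Compound 1 `CC(=O)Nc1cccc(C2CCN(CCCn3c(-c4cccc(Cl)c4)nc4ccccc43)CC2)c1` gives 5 nM, and compound 2 `CC(=O)Nc1cccc(C2CCN(CCCn3c(-c4ccccc4C(F)(F)F)nc4ccccc43)CC2)c1` gives 50 nM. Between them lies one step, a 10-fold higher number from compound 1 to compound 2 (1.00 log units; beyond the scatter), so on the numbers available compound 2 stands as the higher of the two, and no other neighbour is known.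

Compound 3 `COc1ccccc1-c1nc2ccccc2n1CCCN1CCC(c2cccc(NC(C)=O)c2)CC1` is not yet measured. Its difference from compound 2 is methoxy in place of trifluoromethyl on an aromatic carbon. For the measured compounds named here, the only measured step concerns a different exchange, 2-(trifluoromethyl)phenyl in place of 3-chlorophenyl, and therefore says nothing direct about trading trifluoromethyl for methoxy on the same ring. No shown step bears on this change, and the expected size is correspondingly uncertain; the working expectation is a moderate move toward a lower number, not firmly beyond the scatter. Compound 3 is expected to give 25 nM, within 6 nM to 100 nM. The expected step is a 2.0-fold lower number from compound 2 to compound 3 (0.30 log units; within the scatter).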

Compound 3, half-maximal inhibitory concentration: 747 nM
Beside the measured number, compound 3's estimate is 30-fold (1.48 log units) below it; the measured number lies above the stated range.
By their numbers in this assay, from the lowest: compound 1; then compound 2; then compound 3.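

In this assay, methoxy in place of trifluoromethyl on an aromatic carbon, ortho to a large group, gives a 15-fold higher number from compound 2 to compound 3 (1.17 log units; beyond the scatter), so the group held at this place on the ring moves the number well beyond the scatter. Measured against the 3-chlorophenyl compound, the 2-methoxyphenyl group gives a 150-fold higher number from compound 1 to compound 3 (2.17 log units; beyond the scatter), the widest gap among the three compounds. Nothing at hand gives a reason for this result.

As far as these compounds go, three compounds cannot separate the effect of the group itself from that of its place on the ring, and it remains open whether any group at this aromatic carbon can bring the number back towards that of compound 1. A hydroxyl group, a nitrile or an amine there, and the same ring carrying only hydrogen, would test this.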